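Compound 3 to compound 4: chloro in place of phenyl

The compounds below may be only part of what the source reports. "The series", "measured", "known", "first", "only" and "open" are said of these compounds alone.

In a functional assay on IGROV-1 cells (Homo sapiens) for inhibition (a lower number here means a stronger inhibitor, a higher number a weaker inhibitor), compound 1 (`O=C(O)/C=C/c1ccc(-c2ccc(O)cc2)cc1`) gives 89000 nM, compound 2 (`O=C(O)/C=C/c1ccc(-c2ccc(O)c(CC3CCCCC3)c2)cc1`) gives 2580 nM and compound 3 (`O=C(O)/C=C/c1ccc(-c2ccc(O)c(-c3ccccc3)c2)cc1`) gives 19000 nM, so compound 3 stands between the other two. Compound 4 (`O=C(O)/C=C/c1ccc(-c2ccc(O)c(Cl)c2)cc1`) carries chloro in place of phenyl on an aromatic carbon, ortho to a hydroxy group: chloro in place of phenyl on an aromatic carbon. The closest guide is a 4.7-fold lower number from compound 1 to compound 3 (0.67 log units; beyond the scatter), a modest step. The larger 34-fold lower number from compound 1 to compound 2 (1.54 log units; beyond the scatter) and the modest 7.4-fold higher number from compound 2 to compound 3 (0.87 log units; beyond the scatter) show that the size of the step varies with the group. Among the measured compounds shown here, no chloro compound has been measured. A small move toward compound 1 is expected, perhaps not beyond the scatter: a 1.7-fold higher number from compound 3 to compound 4 (0.23 log units; within the scatter). The estimate for compound 4 is 32000 nM, with an expected range of 11000 nM to 85000 nM.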

Compound 4, half-maximal inhibitory concentration: 26000 nM
Beside the measured number, compound 4's estimate is 1.2-fold (0.09 log units) above it; the measured number falls inside the stated range.
By their numbers in this assay, from the lowest: compound 2; then compounds 3 and 4 (each within the scatter of the next); then compound 1.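

In this assay, chloro and phenyl ortho to a hydroxy group cannot be told apart (a 1.4-fold higher number from compound 3 to compound 4 (0.14 log units; within the scatter)). Chloro still improves on hydrogen at this position (a 3.4-fold lower number from compound 1 to compound 4 (0.53 log units; beyond the scatter)), so the gain seen with phenyl does not require an aromatic ring there, while cyclohexylmethyl remains clearly ahead of chloro (a 10-fold higher number from compound 2 to compound 4 (1.00 log units; beyond the scatter)). Nothing available explains these steps. Open questions are what a methoxy group, an amine or a longer alkyl chain would give at this position, and whether the cyclohexylmethyl advantage depends on its ring.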